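A few compounds are considered here, and "the series" means these few. Any claim that something is new, unique, unknown or untested is made for them only; others in the source may bear on it.

Working notes on the series in a functional assay on FM3A cells (Mus musculus) for inhibition, read by cell counting, with a stated time of 2 days; on this read-out lower numbers stand for stronger inhibition and higher numbers for weaker inhibition.

Three compounds have been run. Compound 1 `COc1cccc(-c2nn3cc(-c4cccc(N)c4)nc3s2)c1` gives 29000 nM and is the weakest of the three. Compound 2 `C=C(Br)C(=O)Nc1cccc(-c2cn3nc(CCc4ccccc4)sc3n2)c1` gives 2600 nM. Among the compounds with values here, compound 3 `C=C(Br)C(=O)Nc1cccc(-c2cn3nc(-c4ccccc4)sc3n2)c1` gives 900 nM, the lowest number of the set; the single step in one place, a 2.9-fold lower number from compound 2 to compound 3 (0.46 log units; beyond the scatter), puts compound 3 beyond the scatter of compound 2, and the gap to compound 1 is wider still. Compound 1 differs from compound 3 in more than one place, so its value is only a point of comparison, not a step.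

The next compound, compound 4 `C=C(Br)C(=O)Nc1cccc(-c2cn3nc(-c4cccc(OC)c4)sc3n2)c1`, differs from compound 3 by methoxy in place of hydrogen on an aromatic carbon; read one bond further out, the change is phenyl to 3-methoxyphenyl. Within the data shown here, no measured step bears on this change: the only step so far exchanges phenyl for phenethyl, and a methoxy appears otherwise only in compound 1, whose weak number cannot be tied to that group alone. With nothing in the data that speaks for a shift, no step beyond the scatter is expected in this assay, so the estimate for compound 4 is 900 nM (range 350 nM to 2500 nM), an expected step of no change at the digits printed from compound 3 to compound 4 (within the scatter).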

Compound 4, half-maximal inhibitory concentration: 500 nM
The estimate for compound 4 lay 1.8-fold (0.26 log units) above the measured number, within the range that was stated.
By their numbers in this assay, from the lowest: compounds 4 and 3 (each within the scatter of the next); then compound 2; then compound 1.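

In this assay, methoxy on this aromatic ring gives a 1.8-fold lower number from compound 3 to compound 4 (0.26 log units; within the scatter), so 3-methoxyphenyl and phenyl are not told apart at this position, while a 5.2-fold lower number from compound 2 to compound 4 (0.72 log units; beyond the scatter) places 3-methoxyphenyl, like phenyl, on the lower side of phenethyl. Compound 4 also provides the first one-place link to compound 1: with the methoxy present in both, a 58-fold lower number from compound 1 to compound 4 (1.76 log units; beyond the scatter) ties the large gap to (1-bromoethenyl)carbonyl in place of hydrogen on the nitrogen, and the weak number of compound 1 therefore cannot be attributed to the methoxy. No measurement available here accounts for any of these steps.

The compounds shown leave open whether a hydroxyl, a chlorine or an ethoxy on the same ring would also stay within the scatter of compound 3, and whether methoxy elsewhere on that ring would do the same. They also leave open how much of the step from compound 1 depends on the bromine and the ethenyl part, which a plain acetyl or an unbrominated acryloyl on the nitrogen would help to separate.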